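Amino for Aminomethyl: Cytotoxicity on Canine Kidney Cells

A few compounds are considered here, and "the series" means these few. Any claim that something is new, unique, unknown or untested is made for them only; others in the source may bear on it.

Measured so far:
compound 1, `C[C@H]1[C@H](CN)C[C@@H]2C[C@H]1C2(C)C`, > 300000 nM
compound 2, `CC1(C)[C@@H]2CC[C@@]1(C)[C@@H](CN)C2`, > 300000 nM

Two bicyclic primary amines were examined in an ADME assay on MDCK cells (Canis lupus familiaris) for cytotoxicity, read by CCK-8 assay, with a stated time of 72 h; a higher number here means that more compound is tolerated, a lower number that less compound is tolerated. Compound 1, `C[C@H]1[C@H](CN)C[C@@H]2C[C@H]1C2(C)C`, reaches only a limit of the assay, giving > 300000 nM. Compound 2, `CC1(C)[C@@H]2CC[C@@]1(C)[C@@H](CN)C2`, likewise stops at a limit, with > 300000 nM. Among the compounds with values here, compound 2 therefore stands at the top of what this assay can report, as does the one other measured value; both rest at the limit of > 300000 nM in this assay, at which 2 of the 2 values shown sit. Within the data shown here, no step between two measured compounds is available, so no measured change in this read-out can be drawn on.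

Compound 3, `CC1(C)[C@@H]2CC[C@@]1(C)[C@@H](N)C2`, has yet to be measured. It differs from compound 2 by amino in place of aminomethyl on a saturated ring carbon. Both compounds keep the shared core and a primary amine. Since compound 2 gives > 300000 nM as a limit, no shift beyond the usual scatter is expected in this assay, and the step this estimate implies, a number no higher from compound 2 to compound 3 (the limit leaves the size open), is expected to stay within that scatter. Compound 3 is accordingly estimated at 300000 nM, with a range from 150000 nM to 600000 nM, and most likely it too will be reported only as a limit.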

Compound 3, minimum cytotoxic concentration: > 300000 nM
Compound 3: only a limit was reported (the forecaster's own chance of this, stated with the estimate: 85%); the middle value lies on the limit itself.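

Within the data shown here, compound 2 and compound 3 both stop at a limit in this assay, so the exchange of aminomethyl for amino yields no step that can be read: the limit of > 300000 nM in this assay, at which 3 of the 3 values shown sit. The compounds shown leave open the concentration at which any of them would become cytotoxic, and whether amino and aminomethyl differ at all in this assay.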